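Moving the methyl on the aromatic ring: compound 2 to compound 3

This account rests on a few compounds, and the source may have more. Where it says the series, first, only, none or still open, it means among the compounds named here.

- compound 1 `CCOCn1cc(C(=N)S)c2c(N)ncnc21`: 68000 nM
- compound 2 `Cc1ccc(Cn2cc(C(=N)S)c3c(N)ncnc32)cc1`: 65000 nM

In a functional assay on KB cells (Homo sapiens) for cytotoxicity (a lower number here means a stronger inhibitor, a higher number a weaker inhibitor), compound 2 gives 65000 nM, level with compound 1 within the scatter. The next change leads to compound 3 `Cc1cccc(Cn2cc(C(=N)S)c3c(N)ncnc32)c1`: 3-methylphenyl in place of 4-methylphenyl on a saturated chain carbon bound to an aromatic nitrogen, with 3-methylphenyl in place of 4-methylphenyl on a saturated chain carbon bound to an aromatic nitrogen. Among the measured compounds shown here, only one measured step bears on this place: a 1.0-fold lower number from compound 1 to compound 2 (0.02 log units; within the scatter). For the measured compounds named here, that exchange of ethoxy for 4-methylphenyl left the number unmoved, and no measured step yet covers a shift of the methyl group. The expected step is no change at the digits printed from compound 2 to compound 3 (within the scatter), with no change expected beyond the scatter. Compound 3 is estimated at 65000 nM, with an expected range of 35000 nM to 110000 nM.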

Compound 3, half-maximal inhibitory concentration: 30000 nM
For compound 3 the middle estimate is 2.2-fold (0.34 log units) above the measured one, outside the stated range (below it).
By their numbers in this assay, from the lowest: compound 3; then compounds 2 and 1 (each within the scatter of the next).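

In this assay, the place of the methyl on the aromatic ring counts at this position: 3-methylphenyl in place of 4-methylphenyl brings a 2.2-fold lower number from compound 2 to compound 3 (0.34 log units; beyond the scatter) as a modest step. Against ethoxy, 3-methylphenyl brings a 2.3-fold lower number from compound 1 to compound 3 (0.36 log units; beyond the scatter) as a modest step too, whereas 4-methylphenyl stayed within the scatter of ethoxy. No evidence on the reason for this shift is at hand. Still open, as far as these compounds go, is how an amine or a carboxylic acid in place of this methyl would read in this assay as a result. From the compounds shown here alone, a longer chain there is equally open.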